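Ring Closure at the Ether of a Methanesulfonamide Series

The source may report more compounds than this note shows. Statements on the series, on what has been measured and on what is new or still open speak of the compounds shown alone.

Of the compounds shown here, three of one shared core have been measured in a functional assay on the whole organism (strain Wistar) for inhibition, with Rattus norvegicus as the target, read by paw edema, with stated times of 30 min and 5 h, at a dose of 25 mg/kg by the oral route; a lower number here means a weaker effect, a higher number a stronger effect of the compound at the dose given. Compound 1 `CCOc1cc(C(C)=O)ccc1NS(C)(=O)=O` gives 54.6%. Compound 2 `CCCOc1cc(C(C)=O)ccc1NS(C)(=O)=O` gives 62.1%, and compound 3 `CCCCCCCCOc1cc(C(C)=O)ccc1NS(C)(=O)=O` gives 62.5%. Compound 2 thus stands second highest of the three numbers, but all three lie within the scatter of one another: the step of a number 7.5 percentage points higher from compound 1 to compound 2 (within the scatter) and the step of a number 0.4 percentage points higher from compound 2 to compound 3 (within the scatter) are both within the scatter, as is the step of a number 7.9 percentage points higher from compound 1 to compound 3 (within the scatter).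

The step to the unmeasured compound 4 `CC(=O)c1ccc(NS(C)(=O)=O)c(OC2CCCC2)c1` changes the ether chain of compound 2: cyclopentyl in place of propyl on an oxygen on an aromatic ring. The measured steps that bear on this are the ones that lengthen the same chain, from compound 1 to compound 2 and from compound 2 to compound 3, and neither moved the read-out beyond the scatter. Among the measured compounds shown here, the change to compound 4 is of a different kind, since a ring rather than a longer chain is introduced, and no measured step shows a ring at this oxygen.

Compound 4 is therefore expected to stay close to compound 2, with an estimated step of a number 0.1 percentage points lower from compound 2 to compound 4 (within the scatter), meaning no change beyond the scatter. The estimate for compound 4 in this assay is 62%, with a range from 50% to 72%.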

Compound 4, a percentage reported as inhibition, in the whole organism at one dose (the size of the read-out at that dose, not a potency): 57.4%
Estimate against measurement, compound 4: 4.6 percentage points above; the measured number falls inside the stated range.
By their numbers in this assay, from the lowest: compounds 1, 4, 2 and 3 (each within the scatter of the next).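

Closing the ether chain into a ring at this position leaves the read-out in this assay within the scatter of the open chains: cyclopentyl in place of propyl on an oxygen on an aromatic ring gives a number 4.7 percentage points lower from compound 2 to compound 4 (within the scatter), and cyclopentyl in place of ethyl gives a number 2.8 percentage points higher from compound 1 to compound 4 (within the scatter). The earlier compounds shown here showed only that open chains of different lengths at this oxygen could not be told apart, whereas compound 4 extends this to a ring, so that neither the length of the chain nor the presence of a five-membered ring of carbon only has yet produced a step beyond the scatter. No evidence at hand bears on the reason for this result.

The compounds shown therefore leave open whether any group at this oxygen can move the read-out beyond the scatter, for instance a phenyl ring or a chain ending in an amine or a carboxylic acid. Since each number is the size of the effect at a single dose, they also leave open whether these compounds would give a stronger or weaker effect than one another at any other dose.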